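Swapping chloro for iodo on the benzamide of compound 2

A few compounds are considered here, and "the series" means these few. Any claim that something is new, unique, unknown or untested is made for them only; others in the source may bear on it.

Of the compounds shown here, two have been measured in a functional assay on HL-60 cells (Homo sapiens) for antiproliferative activity, with a stated time of 24 h; a lower number here means a stronger inhibitor, a higher number a weaker inhibitor. Compound 1, `NC(=O)c1c(NC(=O)c2ccccc2Cl)sc2c1CCN(C(=S)Nc1cccc3ccccc13)C2`, gives 13400 nM. Compound 2, `NC(=O)c1c(NC(=O)c2ccccc2Cl)sc2c1CCN(C(=S)Nc1ccccc1Br)C2`, gives 9090 nM. These two share a core and differ only at the thiourea end: the change a 1.5-fold lower number from compound 1 to compound 2 (0.17 log units; within the scatter) puts 2-bromophenyl in place of naphthalen-1-yl on an amide-type nitrogen. Compound 2 therefore stands beside compound 1, the two numbers falling within the usual scatter of each other, so no ranking between them can be claimed.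

Compound 3, `NC(=O)c1c(NC(=O)c2ccccc2I)sc2c1CCN(C(=S)Nc1ccccc1Br)C2`, keeps the 2-bromophenyl thiourea of compound 2 and alters the other end of the molecule: iodo in place of chloro on an aromatic carbon. For the measured compounds named here, no measured step touches this position; the only step available, from compound 1 to compound 2, concerns the thiourea nitrogen and gives no guidance about the benzamide ring. With nothing to point either way, and a halogen exchanged for another halogen, the expectation in this assay is a step of no more than the scatter, a 1.0-fold lower number from compound 2 to compound 3 (0.00 log units; within the scatter). Compound 3 is thus estimated at 9000 nM, with a plausible range from 4000 nM to 20000 nM.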

Compound 3, half-maximal inhibitory concentration: 18900 nM
Estimate against measurement, compound 3: 2.1-fold (0.32 log units) below, within the range that was stated.
By their numbers in this assay, from the lowest: compounds 2, 1 and 3 (each within the scatter of the next, the first and the last beyond it).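

For the compounds shown here, the halogen on the benzamide ring, which no earlier step touched, proves to matter in this assay: iodo in place of chloro on an aromatic carbon, ortho to a large group, gives a 2.1-fold higher number from compound 2 to compound 3 (0.32 log units; beyond the scatter) and counts as a modest change. So exchanging a single atom at this end of the molecule can shift the read-out, while the one earlier step, at the thiourea end, gave a 1.5-fold lower number from compound 1 to compound 2 (0.17 log units; within the scatter) and could not be ranked. Nothing measured here bears on why the iodo compound gives the higher number, so the reason for this step remains unknown.

On these data alone, only chloro and iodo have been seen at this position, and both with the 2-bromophenyl thiourea, so it remains open whether fluoro, methyl, methoxy or a plain hydrogen would give a lower or a higher number than chloro. As far as these compounds go, it is also open whether the same exchange of chloro for iodo would produce a step of similar size and direction with the naphthalen-1-yl thiourea in place of the 2-bromophenyl one.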